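Sulfonyl cinnamamides: methyl to bromo on the sulfonyl ring

This account rests on a few compounds, and the source may have more. Where it says the series, first, only, none or still open, it means among the compounds named here.

Measured so far in a functional assay on B16-F10 cells (Mus musculus) for antiproliferative activity, read by ELISA and MTT assay, with a stated time of 48 h; on this read-out higher numbers stand for weaker inhibition and lower numbers for stronger inhibition:
- compound 1, `O=C(/C=C/c1ccccc1)NS(=O)(=O)c1ccc(Br)cc1`, gives 3.9 ug/mL
- compound 2, `O=C(/C=C/c1ccc(F)cc1)NS(=O)(=O)c1ccccc1`, gives 2.1 ug/mL
- compound 3, `Cc1ccc(S(=O)(=O)NC(=O)/C=C/c2ccc(F)cc2)cc1`, gives 4.8 ug/mL

Going by the values given here, compound 3 holds the highest number of the three in this assay; compound 1 sits within the scatter of it, while compound 2 is separated from it by the one measured step, a 2.3-fold higher number from compound 2 to compound 3 (0.36 log units; beyond the scatter).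

Compound 4, `O=C(/C=C/c1ccc(F)cc1)NS(=O)(=O)c1ccc(Br)cc1`, keeps the shared core of compound 3 and differs in one place: bromo in place of methyl on an aromatic carbon. Among the compounds with values here, no measured pair shows this very change. Compound 1 carries a bromo on the same ring as compound 4 but lacks the fluoro of the cinnamoyl part, and compound 2 carries that fluoro but has the sulfonyl ring unsubstituted, so their numbers only bracket the neighbourhood. Compound 1 and compound 3 lie within the scatter of each other, which speaks for a small effect of what sits on the sulfonyl ring when a methyl or a bromo is present.

Compound 4 is therefore expected to stay close to compound 3 in this assay, with an estimated step of a 1.3-fold lower number from compound 3 to compound 4 (0.10 log units; within the scatter) that is unlikely to exceed the scatter. The estimate for compound 4 is 3.8 ug/mL, with a range from 1.8 ug/mL to 8 ug/mL.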

Compound 4, half-maximal inhibitory concentration: 2.8 ug/mL
Estimate against measurement, compound 4: 1.4-fold (0.13 log units) above; the range from low to high includes it.
By their numbers in this assay, from the lowest: compounds 2, 4, 1 and 3 (each within the scatter of the next, the first and the last beyond it).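

Working notes on the sulfonyl ring: the position now carries hydrogen, methyl and bromo on the same fluoro-bearing core, and in this assay the direct exchange gives a 1.7-fold lower number from compound 3 to compound 4 (0.23 log units; within the scatter) and so stays inside the usual spread of repeats. Bromo in place of hydrogen gives a 1.3-fold higher number from compound 2 to compound 4 (0.12 log units; within the scatter) while methyl in place of hydrogen gives a 2.3-fold higher number from compound 2 to compound 3 (0.36 log units; beyond the scatter) so at this position only the methyl step clears the scatter, and compound 4 cannot be told apart from either neighbour. Going by these compounds alone, with bromo held on the sulfonyl ring, the first reading of fluoro in place of hydrogen on the cinnamoyl ring gives a 1.4-fold lower number from compound 1 to compound 4 (0.14 log units; within the scatter) and thus shows no separable effect of that fluoro in this setting.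

On these data alone, the response of this position to an amine, a carboxylic acid or a longer alkyl chain in place of the 4-methylphenyl methyl remains open, as does whether any group can move the number well beyond the narrow band seen so far. Nothing available accounts for these steps.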